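This account rests on a few compounds, and the source may have more. Where it says the series, first, only, none or still open, it means among the compounds named here.

Compound 1 `CC(C#CCn1ccnc1)N1CCCC1=O`; compound 2 `CC(C#CCN(C)C)N1CCCC1=O`; compound 3 `COC(=O)N(C)C(C)C#CCn1ccnc1`.

In a functional assay on the whole organism for agonist activity, with Mus musculus as the target (a higher number here means that more compound is needed for the effect, a lower number that less compound is needed), compound 1 gives only a limit of the assay, > 100 mg/kg, which is the limit of > 100 mg/kg in this assay, at which 1 of the 3 values shown sits. In this assay compound 2 gives 6.6 mg/kg. In this assay compound 3 gives 8 mg/kg, and this value and that of compound 2 lie within the usual scatter of each other. The change from compound 1 to compound 2 is dimethylamino in place of 1H-imidazol-1-yl on a saturated chain carbon bound to a triple-bonded carbon, and it brought an at least 15-fold lower number from compound 1 to compound 2 (1.18 log units; beyond the scatter). How the core of compound 1 and the core of compound 3 differ is not broken down here. Compound 4 `COC(=O)N(C)C(C)C#CCN(C)C` carries the same change on the core of compound 3: dimethylamino in place of 1H-imidazol-1-yl on a saturated chain carbon bound to a triple-bonded carbon. Beside the earlier step, the step expected in this assay is a 5.3-fold lower number from compound 3 to compound 4 (0.73 log units; beyond the scatter), and this rests on an at least 15-fold lower number from compound 1 to compound 2 (1.18 log units; beyond the scatter). Compound 4 is therefore estimated at 1.5 mg/kg, between 0.3 mg/kg and 8 mg/kg.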

Compound 4, dose for half-maximal effect: 17.3 mg/kg
Compound 4: middle estimate off by 12-fold (1.06 log units), on the low side, and the stated range ends below it.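

On the core of compound 3, dimethylamino in place of 1H-imidazol-1-yl gives a 2.2-fold higher number from compound 3 to compound 4 (0.33 log units; beyond the scatter) in this assay, so the change does not carry over from the core of compound 1 in this series. The outcome of this change depends on the core in these two pairs, and the two steps run in opposite directions: the same change on two cores in this assay, an at least 15-fold lower number (1.18 log units; beyond the scatter) from compound 1 to compound 2 and a 2.2-fold higher number (0.33 log units; beyond the scatter) from compound 3 to compound 4, at least 32-fold (1.51 log units) apart, beyond the scatter of two such steps. This does not show which part of the cores sets the difference, and the earlier step has no exact size, since compound 1 stands at a limit: the limit of > 100 mg/kg in this assay, at which 1 of the 4 values shown sits.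

The compounds shown leave open whether another amine, such as pyrrolidin-1-yl or diethylamino, would follow the core of compound 1 or that of compound 3. They also leave open how the change behaves on a third core, such as one with a longer chain.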